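The source may report more compounds than this note shows. Statements on the series, on what has been measured and on what is new or still open speak of the compounds shown alone.

Working notes on the series. Compound 1 `CCN(CC)c1ccc2nc(-c3ccccc3OC(F)(F)F)[nH]c(=O)c2c1` carries the diethylamino group on the shared core and, in an assay on isolated protein for inhibition of DNA topoisomerase 1 (Homo sapiens), with a stated time of 30 min, tested at 20 uM (a higher number here means a stronger effect of the compound at the concentration tested, a lower number a weaker effect), compound 1 gives 0%. Compound 2 `Cc1ccc2nc(-c3cccc4ccccc34)[nH]c(=O)c2c1` carries methyl in the same place and a naphthalen-1-yl group on the other side; in this assay compound 2 gives "not determined" (no result reported), so there is no number for compound 2 to stand on, and its position in the series is open.

Compound 3 `CCN(CC)c1ccc2nc(-c3cccc4ccccc34)[nH]c(=O)c2c1` is compound 2 with one change: diethylamino in place of methyl on an aromatic carbon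

Going by the values given here, no measured step between compounds is available to size this change in this assay, and compound 2 itself has no number, so the size of the step from compound 2 to compound 3 cannot be anchored; no movement beyond the scatter is assumed in either direction. Among the compounds with values here, the only fixed point is compound 1, which carries the same diethylamino group and gives 0% in this assay. On that basis compound 3 is expected to sit low as well, with an estimated inhibition of 5%, in a range from 0% to 25%.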

Compound 3, a percentage reported as inhibition, at one concentration (the size of the read-out at that concentration, not a potency): 25.5%
For compound 3 the middle estimate is 20.5 percentage points below the measured one, outside the stated range (above it).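

No step can be read between compound 2, which has no reported result in this assay, and compound 3. The compounds shown leave open how far replacing methyl with diethylamino moves inhibition in this assay. No available evidence bears on the result for compound 3.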